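A few compounds are considered here, and "the series" means these few. Any claim that something is new, unique, unknown or untested is made for them only; others in the source may bear on it.

Measured in a functional assay on T29Kt1 cells (Homo sapiens) for cytotoxicity, read by sulforhodamine B assay, with a stated time of 3 days; a lower number here means a stronger inhibitor, a higher number a weaker inhibitor:

Compound 1 (`CC(O)c1cn(Cc2ccc(Cl)cc2)c2ccccc12`): 19900 nM
Compound 2 (`COCc1cn(Cc2ccc(Cl)cc2)c2ccccc12`): 7940 nM

Among the compounds with values here, of these two, compound 2 holds the lower number, at 7940 nM, and the only neighbour it can be set against is compound 1 at 19900 nM. Within the data shown here, the single measured step is a 2.5-fold lower number from compound 1 to compound 2 (0.40 log units; beyond the scatter), a modest change that lies beyond the scatter.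

Compound 3 (`O=C(NC1CCCCC1)OCc1cn(Cc2ccc(Cl)cc2)c2ccccc12`) keeps the core of compound 2 and alters one group, with cyclohexylcarbamoyl in place of methyl on an oxygen on a saturated carbon. Among the measured compounds shown here, no measured step covers this exchange. For the measured compounds named here, the step of a 2.5-fold lower number from compound 1 to compound 2 (0.40 log units; beyond the scatter) is the only guide to how far a change in this side chain has moved the number, and it involved a far smaller group. A step of similar or slightly larger size is therefore expected in this assay, tentatively toward a lower number, although the data do not settle the direction. The expected change is a 2.0-fold lower number from compound 2 to compound 3 (0.30 log units; within the scatter). For compound 3 the estimated value is 4000 nM, with an expected range from 800 nM to 15000 nM.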

Compound 3, half-maximal inhibitory concentration: 200 nM
The estimate for compound 3 lay 20-fold (1.30 log units) above the measured number, outside the stated range (below it).
By their numbers in this assay, from the lowest: compound 3; then compound 2; then compound 1.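

The exchange of methyl for cyclohexylcarbamoyl on an oxygen on a saturated carbon gives a 40-fold lower number from compound 2 to compound 3 (1.60 log units; beyond the scatter) in this assay, a large step that far exceeds the modest 2.5-fold lower number from compound 1 to compound 2 (0.40 log units; beyond the scatter). Within the data shown here, this position therefore accepts a much larger group than the earlier compounds showed, and the number can fall much further than the earlier pair suggested. The entering group brings several features at once: a six-membered non-aromatic ring of carbon only, a double bond outside aromatic rings, a hydrogen-bond donor and a hydrogen-bond acceptor, and no information available here explains why the number falls so far.

With all these features arriving in one exchange, the compounds shown leave open whether the step belongs to the cyclohexyl ring, to the carbamoyl linkage or to the two together; a simple acetyl group or an ethylcarbamoyl group on the same oxygen would begin to separate them. They also leave open whether a phenylcarbamoyl group or a cyclopentylcarbamoyl group would hold the number at the level of compound 3 or move it further.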